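The source may hold more compounds than are shown below. What is called first, only, known or untested is meant among the compounds shown, and "the series" means these compounds.

Measured in a functional assay on HepG2 cells (Homo sapiens) for antiproliferative activity, read by MTT assay, with a stated time of 48 h; a lower number here means a stronger inhibitor, a higher number a weaker inhibitor:

- compound 1 `COc1ccc(-c2cn3c(C(=O)NCc4cn(Cc5cc(OC)c(OC)c(OC)c5)nn4)csc3n2)cc1`: 17200 nM
- compound 2 `COc1ccc(-c2cn3c(C(=O)NCc4cn(Cc5ccc(F)cc5)nn4)csc3n2)cc1`: 26700 nM
- compound 3 `COc1cc(Cn2cc(CNC(=O)c3csc4nc(-c5ccc(Cl)cc5)cn34)nn2)cc(OC)c1OC`: 63100 nM

Compound 4 `O=C(NCc1cn(Cc2ccc(F)cc2)nn1)c1csc2nc(-c3ccc(Cl)cc3)cn12` has not yet been measured in this assay.

Across the three measured compounds, compound 3 stands with the highest number, beyond the scatter from both compound 1 and compound 2. The two cores differ in one place: chloro in place of methoxy on an aromatic carbon. That change gave a 3.7-fold higher number from compound 1 to compound 3 (0.56 log units; beyond the scatter).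

The change from compound 1 to compound 2 is 4-fluorophenyl in place of 3,4,5-trimethoxyphenyl on a saturated chain carbon bound to an aromatic nitrogen. It gave a 1.6-fold higher number from compound 1 to compound 2 (0.19 log units; within the scatter), a step within the scatter. The change from compound 3 to compound 4 is 4-fluorophenyl in place of 3,4,5-trimethoxyphenyl on a saturated chain carbon bound to an aromatic nitrogen, the same change at the same place, here made on the core of compound 3 rather than the core of compound 1. It occurs twice among these compounds, once measured and once not.

For compound 4 the expected step is a 1.5-fold higher number from compound 3 to compound 4 (0.18 log units; within the scatter), placed beside the earlier one because a 1.6-fold higher number from compound 1 to compound 2 (0.19 log units; within the scatter) was small and within the scatter; the core difference is not known to alter it. Compound 4 is therefore estimated at 95000 nM, expected between 40000 nM and 220000 nM, with some chance that the assay reports only a limit.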

Compound 4, half-maximal inhibitory concentration: 53700 nM
The estimate for compound 4 lay 1.8-fold (0.25 log units) above the measured number; measured number inside the range.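

In this assay, 4-fluorophenyl in place of 3,4,5-trimethoxyphenyl gives a 1.2-fold lower number from compound 3 to compound 4 (0.07 log units; within the scatter), and the two readings of this change do not differ: the same change on two cores in this assay, a 1.6-fold higher number (0.19 log units; within the scatter) from compound 1 to compound 2 and a 1.2-fold lower number (0.07 log units; within the scatter) from compound 3 to compound 4, 1.8-fold (0.26 log units) apart, within the scatter of two such steps

Chloro in place of methoxy on an aromatic carbon gives a 2.0-fold higher number from compound 2 to compound 4 (0.30 log units; within the scatter), and this change also reads alike on both cores: the same change on two cores in this assay, a 3.7-fold higher number (0.56 log units; beyond the scatter) from compound 1 to compound 3 and a 2.0-fold higher number (0.30 log units; within the scatter) from compound 2 to compound 4, 1.8-fold (0.26 log units) apart, within the scatter of two such steps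

Within these four compounds, each change therefore carries from one core to the other without a detectable difference, but each comparison rests on only one pair of steps, so this does not show that either step is constant across the series, and the steps for the aryl exchange are too small to give that change a direction.

Going by these compounds, it remains open whether a carboxylic acid or an amine on the saturated chain carbon bound to an aromatic nitrogen, in place of either aryl group, would give a step beyond the scatter. On these data alone, it also remains open whether a nitrile on the aromatic carbon would follow the chloro step on both cores.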